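Methylamino in place of hydroxy: compound 2 to compound 3

This account rests on a few compounds, and the source may have more. Where it says the series, first, only, none or still open, it means among the compounds named here.

In a functional assay on CCRF-CEM cells (Homo sapiens) for inhibition, with a stated time of 72 h (a higher number here means a weaker inhibitor, a lower number a stronger inhibitor), compound 1 `CC(C)(C)N(CC(=O)N(Cc1ccccc1)C1(C(=O)NCc2ccccc2)CCN(Cc2ccccc2)CC1)C(=O)O` gives 21000 nM, a real number that places it on the scale. Compound 2 `CC(C)(C)OC(=O)N[C@@H](CC(=O)O)C(=O)N(Cc1ccccc1)C1(C(=O)NCc2ccccc2)CCN(Cc2ccccc2)CC1` gives only a limit of the assay, > 200000 nM, and not a number. On these data alone, its exact place therefore stays unknown.

Compound 3 `CNC(=O)C[C@H](NC(=O)OC(C)(C)C)C(=O)N(Cc1ccccc1)C1(C(=O)NCc2ccccc2)CCN(Cc2ccccc2)CC1` keeps the rest of compound 2 and carries methylamino in place of hydroxy on a carbonyl carbon. Within the data shown here, no measured pair in this small set shows what such a change does, so any forecast is rough. Among the measured compounds shown here, the expectation leans on compound 1 at 21000 nM, the only exact value available. The estimated change is an at least 5.0-fold lower number from compound 2 to compound 3 (0.69 log units; beyond the scatter), towards stronger inhibition and probably beyond the usual scatter. For compound 3 the estimate is 40000 nM, with an expected range from 10000 nM to 150000 nM.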

Compound 3, half-maximal inhibitory concentration: 63000 nM
Compound 3: the middle estimate sits 1.6-fold (0.20 log units) below what was measured, and the stated range covers the measured number.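

In this assay, replacing hydroxy with methylamino on this carbonyl carbon gives an at least 3.1-fold lower number from compound 2 to compound 3 (0.50 log units; beyond the scatter). This size is only a minimum, because compound 2 stands at a limit of the assay and has no exact number: the limit of > 200000 nM in this assay, at which 1 of the 3 values shown sits. The result shows that a free carboxy group at this position is not needed for a measurable effect on these cells, since compound 3, which carries methylcarbamoyl instead, lands on the scale with an exact number.

The compounds shown leave open whether the stronger inhibition comes from losing the hydroxy or from the methyl on the new nitrogen. On these data alone, how an amino or an ethylamino group on the same carbonyl carbon would read in this assay also stays open, and the true size of this step stays unknown.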